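Swapping a chloro for trifluoromethyl on the ester ring

The source may report more compounds than this note shows. Statements on the series, on what has been measured and on what is new or still open speak of the compounds shown alone.

Measured compounds:
compound 1 `COc1cccc(C(=O)Oc2cc3c(cc2C)[C@@H](C(C)C)CC=C3C)c1`, 24.2%
compound 2 `CC1=CC[C@H](C(C)C)c2cc(C)c(OC(=O)c3ccccc3)cc21`, 37%
compound 3 `CC1=CC[C@H](C(C)C)c2cc(C)c(OC(=O)c3cccc(Cl)c3)cc21`, 30.6%

The three compounds share one core and differ only in a single group on the aromatic ring of the ester. In a functional assay on SK-LU-1 cells (Homo sapiens) for antiproliferative activity, read by sulforhodamine B assay, with a stated time of 48 h, tested at 50 uM (a higher number here means more inhibition at the concentration tested (going by the name of the read-out), a lower number less inhibition), compound 3 gives 30.6%, the second highest of the three numbers; compound 2 is a number 6.4 percentage points lower from compound 2 to compound 3 (within the scatter) and compound 1 is a number 6.4 percentage points higher from compound 1 to compound 3 (within the scatter), so all three sit within the usual scatter of one another. Compound 4 `CC1=CC[C@H](C(C)C)c2cc(C)c(OC(=O)c3cccc(C(F)(F)F)c3)cc21` is not yet measured. It differs from compound 3 by trifluoromethyl in place of chloro on an aromatic carbon. Among the compounds with values here, two measured steps touch this position: from compound 2 to compound 3 the change was a number 6.4 percentage points lower from compound 2 to compound 3 (within the scatter), and from compound 1 to compound 3 it was a number 6.4 percentage points higher from compound 1 to compound 3 (within the scatter). Within the data shown here, neither moved the number beyond the scatter, and no measured step shows trifluoromethyl itself. The step to compound 4 is therefore expected to stay within the scatter, a number 0.4 percentage points higher from compound 3 to compound 4 (within the scatter). Compound 4 is estimated at 31%, within 18% to 44%.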

Compound 4, a percentage reported as inhibition, at one concentration (the size of the read-out at that concentration, not a potency): 18.3%
Beside the measured number, compound 4's estimate is 12.7 percentage points above it; the range from low to high includes it.
By their numbers in this assay, from the lowest: compounds 4, 1, 3 and 2 (each within the scatter of the next, the first and the last beyond it).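

In this assay, the choice of group on this aromatic carbon can matter: chloro had stayed within the scatter of both hydrogen and methoxy, yet trifluoromethyl gives a number 12.3 percentage points lower from compound 3 to compound 4 (beyond the scatter) and a number 18.7 percentage points lower from compound 2 to compound 4 (beyond the scatter) on the same ester ring. Methoxy and trifluoromethyl cannot be told apart, with a number 5.9 percentage points lower from compound 1 to compound 4 (within the scatter) in this comparison, so both stand beyond the scatter of the unsubstituted compound 2, while chloro does not. Nothing available explains why chloro and trifluoromethyl differ here.

The compounds shown leave open how an amine, a carboxylic acid or a longer chain would read on this same aromatic carbon. Going by these compounds, every number also comes from a single concentration, so how these compounds compare in potency remains open.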